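The source may hold more compounds than are shown below. What is called first, only, known or untested is meant among the compounds shown, and "the series" means these compounds.

Compound 1 `COc1cc(NC(=O)/C=C/c2cccc(OCc3ccccc3)c2)cc(OC)c1OC`: 21700 nM
Compound 2 `C=C(Br)C(=O)Nc1cccc(/C=C/C(=O)Nc2ccccc2)c1`: 3900 nM
Compound 3 `C=C(Br)C(=O)Nc1cccc(/C=C/C(=O)Nc2ccc(F)cc2)c1`: 4800 nM

In a functional assay on LoVo cells (Homo sapiens) for inhibition, read by MTT assay, with a stated time of 72 h (a higher number here means a weaker inhibitor, a lower number a stronger inhibitor), compound 3 gives 4800 nM. This value lies within the scatter of compound 2 and clearly below compound 1. Compound 4 `C=C(Br)C(=O)Nc1cccc(/C=C/C(=O)Nc2cccc(F)c2)c1` has the same atoms as compound 3, joined differently: 3-fluorophenyl in place of 4-fluorophenyl on an amide-type nitrogen. For the measured compounds named here, only one measured step bears on this change: fluoro in place of hydrogen on an aromatic carbon gave a 1.2-fold higher number from compound 2 to compound 3 (0.09 log units; within the scatter). The data hold no direct comparison of the two fluorophenyl groups, but that small step suggests little change here. The expected change, no larger than the scatter, is a 1.1-fold lower number from compound 3 to compound 4 (0.03 log units; within the scatter). For compound 4 the estimated value is 4500 nM, with an expected range of 2400 nM to 8500 nM.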

Compound 4, half-maximal inhibitory concentration: 1000 nM
For compound 4 the middle estimate is 4.5-fold (0.65 log units) above the measured one, and the stated range ends above it.
By their numbers in this assay, from the lowest: compound 4; then compounds 2 and 3 (each within the scatter of the next); then compound 1.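

In this assay the place of the fluoro matters: 3-fluorophenyl in place of 4-fluorophenyl gives a 4.8-fold lower number from compound 3 to compound 4 (0.68 log units; beyond the scatter) with the same atoms. Fluoro in place of hydrogen is therefore not always a silent change, since it gives a 3.9-fold lower number from compound 2 to compound 4 (0.59 log units; beyond the scatter) as 3-fluorophenyl, against a 1.2-fold higher number from compound 2 to compound 3 (0.09 log units; within the scatter) as 4-fluorophenyl. The data offer no explanation for this difference. On these data alone, whether 3-chlorophenyl or 3-methoxyphenyl on the amide-type nitrogen would give a number like that of 3-fluorophenyl remains open.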